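Oxetane for Azetidine: Expected Cytotoxicity of Compound 3

The compounds below may be only part of what the source reports. "The series", "measured", "known", "first", "only" and "open" are said of these compounds alone.

Measured compounds:
Compound 1, `CS(=O)(=O)CCCn1c(Cn2c(=O)n(C3CC3)c3ccncc32)cc2cc(Cl)ccc21`: in an ADME assay on HeLa cells (Homo sapiens) for cytotoxicity, read by ATP content, with a stated time of 3 days (on this read-out higher numbers stand for lower toxicity in this test and lower numbers for higher toxicity in this test), compound 1 gives > 50000 nM, a limit of the assay rather than a number.
Compound 2, `CS(=O)(=O)CCCn1c(Cn2c(=O)n(C3CNC3)c3ccncc32)cc2cc(Cl)ccc21`: in this assay compound 2 gives > 50000 nM, likewise a limit of the assay.

Compound 2 therefore stands at the top of what this assay reports. Among the measured compounds shown here, the one measured step, a step that the two limits leave unreadable from compound 1 to compound 2, cannot be read in size or direction, since both ends sit at a limit; this is summed up by the limit of > 50000 nM in this assay, at which 2 of the 2 values shown sit.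

Compound 3, `CS(=O)(=O)CCCn1c(Cn2c(=O)n(C3COC3)c3ccncc32)cc2cc(Cl)ccc21`, differs from compound 2 in one place: oxetan-3-yl in place of azetidin-3-yl on an aromatic nitrogen. For the measured compounds named here, the only measured step bears on the same position, and it is unreadable, so it gives no size to carry forward. Going by the values given here, nothing among the measured values points to a step beyond the scatter, and compound 3 is expected to remain at the limit, with a step that the limit leaves unreadable from compound 2 to compound 3 expected from compound 2 to compound 3. The estimate for compound 3 in this assay is 60000 nM, with a range from 30000 nM to 200000 nM, most likely reported again only as a limit.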

Compound 3, half-maximal cytotoxic concentration: > 50000 nM
Compound 3 gave a limit, no number; the forecaster's own chance of this, stated with the estimate: 85%; the middle value does not contradict the limit.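

In this assay compound 3 gives > 50000 nM, a limit of the assay and not a number. The steps from compound 1 and from compound 2 to compound 3 therefore cannot be read: the limit of > 50000 nM in this assay, at which 3 of the 3 values shown sit. The compounds shown leave open whether cyclopropyl, azetidin-3-yl and oxetan-3-yl on the aromatic nitrogen differ at all in this assay.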